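The source may report more compounds than this note shows. Statements on the series, on what has been measured and on what is new or still open speak of the compounds shown alone.

Measured so far in a functional assay (Rattus norvegicus) for antiproliferative activity; a higher number here means a weaker inhibitor, a lower number a stronger inhibitor:
compound 1 `Cc1nc2c([nH]1)C(=O)/C(=N/c1ccc(Cl)cc1Cl)C(Cl)=C2O` gives 800 nM;
compound 2 `Cc1nc2c([nH]1)C(=O)/C(=N/c1cccc(Br)c1)C(Cl)=C2O` gives 1000 nM;
compound 3 `Cc1nc2c([nH]1)C(=O)/C(=N/c1ccc(F)c(F)c1F)C(Cl)=C2O` gives 800 nM.

All three share one core and differ only in the aryl group on the double-bonded nitrogen. Compound 2 stands level with the other two: compound 1 and compound 3 each give a number within the scatter of its own, so no order among the three can be read from these values. Compound 4 `Cc1nc2c([nH]1)C(=O)/C(=N/c1ccc(Cl)cc1)C(Cl)=C2O` is not yet measured. It differs from compound 2 by 4-chlorophenyl in place of 3-bromophenyl on a double-bonded nitrogen. Going by the values given here, no single-point step between measured compounds is known, and the three aryl variants seen give no separation beyond the scatter. The step from compound 2 to compound 4 is therefore expected to be no more than the scatter, a 1.1-fold lower number from compound 2 to compound 4 (0.05 log units; within the scatter). Compound 4 is estimated at 900 nM, in the range 450 nM to 1800 nM.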

Compound 4, half-maximal inhibitory concentration: 2800 nM
The estimate for compound 4 lay 3.1-fold (0.49 log units) below the measured number, and the stated range ends below it.
By their numbers in this assay, from the lowest: compounds 1, 3 and 2 (each within the scatter of the next); then compound 4.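

In this assay, the aryl group on the double-bonded nitrogen now shows an effect beyond the scatter: 4-chlorophenyl in place of 3-bromophenyl gives a 2.8-fold higher number from compound 2 to compound 4 (0.45 log units; beyond the scatter) on the shared core. A single change in the aryl group also separates two compounds, as hydrogen in place of chloro on an aromatic carbon gives a 3.5-fold higher number from compound 1 to compound 4 (0.54 log units; beyond the scatter) in this series. Nothing available explains either step.

The compounds shown leave open whether the step to compound 4 follows the halogen or its place, which 3-chlorophenyl or 4-bromophenyl would separate. They also leave open how an amine on that ring would read.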